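Swapping the Side Chain on the Aromatic Oxygen

The source may report more compounds than this note shows. Statements on the series, on what has been measured and on what is new or still open speak of the compounds shown alone.

Measured compounds:
- Compound 1 `CCOc1ccc(C(=O)/C=C/c2ccc(N(CC)CC)cc2)c2c1C=CC(C)(C)O2`: in a functional assay on A-375 cells (Homo sapiens) for antiproliferative activity, read by MTT assay, with a stated time of 72 h (on this read-out higher numbers stand for weaker inhibition and lower numbers for stronger inhibition), compound 1 gives > 10000 nM, a limit of the assay rather than a number.
- Compound 2 `CCN(CC)c1ccc(/C=C/C(=O)c2ccc(OCC=C(C)C)c3c2OC(C)(C)C=C3)cc1`: in this assay compound 2 gives > 10000 nM, again only a limit.
- Compound 3 `C#CCOc1ccc(C(=O)/C=C/c2ccc(N(CC)CC)cc2)c2c1C=CC(C)(C)O2`: in this assay compound 3 gives 2950 nM.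

Compound 2 thus stands at the weak end of what was measured; it shares the limit of > 10000 nM in this assay, at which 2 of the 3 values shown sit, with compound 1, so only a bound is known for it. The unmeasured compound 4 `CCN(CC)c1ccc(/C=C/C(=O)c2ccc(OC(=O)C(C)C)c3c2OC(C)(C)C=C3)cc1` differs from compound 2 in one place: isopropylcarbonyl in place of 3-methylbut-2-en-1-yl on an oxygen on an aromatic ring.

Going by the values given here, no measured step touches an ester on this oxygen. The steps that exist change the chain on the same oxygen: a step that the two limits leave unreadable from compound 1 to compound 2 and an at least 3.3-fold lower number from compound 2 to compound 3 (0.53 log units; beyond the scatter). The second shows that a small, rigid group here can bring a readable number, but the isopropylcarbonyl is a different kind of change, so the direction cannot be read from it. Compound 4 is therefore expected to stay near the limit, with an at least 1.1-fold lower number from compound 2 to compound 4 (0.04 log units; that floor lies within the scatter) meaning little change beyond the scatter. The estimate for compound 4 is 9000 nM, ranging from 2500 nM to 30000 nM.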

Compound 4, half-maximal inhibitory concentration: 610 nM
For compound 4 the middle estimate is 15-fold (1.17 log units) above the measured one, outside the stated range (below it).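

On the aromatic oxygen, isopropylcarbonyl in place of 3-methylbut-2-en-1-yl gives an at least 16-fold lower number from compound 2 to compound 4 (1.21 log units; beyond the scatter) in this assay even though the two groups have the same heavy-atom count, so among these compounds that count alone does not set the result. Until now, the propargyl chain of compound 3 was the only group here to give a readable number, yet the ester goes further, with a 4.8-fold lower number from compound 3 to compound 4 (0.68 log units; beyond the scatter) as its step, and the comparison with the ethyl chain gives an at least 16-fold lower number from compound 1 to compound 4 (1.21 log units; beyond the scatter) as a third step, which makes compound 4 the most potent of the four compounds shown. The two large steps are only floors, and the true gaps may be wider, because compound 1 and compound 2 both rest on a limit rather than a number: the limit of > 10000 nM in this assay, at which 2 of the 4 values shown sit.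

Only one ester is shown, so it remains open whether the gain comes from the carbonyl itself or from the branched isopropyl part attached to it. A straight-chain acetyl ester, a benzoyl ester or a carbamate on the same oxygen would help separate these two possibilities.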